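This account rests on a few compounds, and the source may have more. Where it says the series, first, only, none or still open, it means among the compounds named here.

Among the compounds with values here, compound 3 `COc1ccccc1NC1=CC(=O)c2nc3n(c2C1=O)[C@H]1OC[C@@H](O)[C@H]1OC3` is the only member of the series with a number in a functional assay on HeLa cells (Homo sapiens) for inhibition, read by sulforhodamine B assay; a lower number here means a stronger inhibitor, a higher number a weaker inhibitor: compound 3 gives 2950 nM. Compound 1 `O=C1C(Nc2ccccc2)=CC(=O)c2c1nc1n2[C@H]2OC[C@@H](O)[C@H]2OC1` reaches only a limit in this assay, where compound 1 gives > 8000 nM. Compound 2 `O=C1C(N2CCCC2)=CC(=O)c2c1nc1n2[C@H]2OC[C@@H](O)[C@H]2OC1` likewise reaches only a limit, where compound 2 gives > 16000 nM. The step that the two limits leave unreadable from compound 1 to compound 2 is thus unreadable, as the limit of > 8000 nM in this assay, at which 1 of the 3 values shown sits, and the limit of > 16000 nM in this assay, at which 1 of the 3 values shown sits, show. Compound 4 `COc1cccc(NC2=CC(=O)c3nc4n(c3C2=O)[C@H]2OC[C@@H](O)[C@H]2OC4)c1` differs from compound 3 by 3-methoxyphenyl in place of 2-methoxyphenyl on an amine nitrogen. Within the data shown here, no measured step touches this change, so no direction can be read from the series. The expectation for compound 4 is a step of a 1.0-fold higher number from compound 3 to compound 4 (0.01 log units; within the scatter) no larger than the scatter. Compound 4 is estimated in this assay at 3000 nM, between 1000 nM and 9000 nM.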

Compound 4, half-maximal inhibitory concentration: 4280 nM
Compound 4: the middle estimate sits 1.4-fold (0.15 log units) below what was measured, within the range that was stated.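

The series now has its first readable step, 3-methoxyphenyl in place of 2-methoxyphenyl on an amine nitrogen: a 1.5-fold higher number from compound 3 to compound 4 (0.16 log units; within the scatter). Compound 3 and compound 4 cannot be told apart in this assay, so between these two compounds the place of the methoxy group on this ring has no readable effect. Both carry a number, while compound 1, without methoxy, gives only a limit: the limit of > 8000 nM in this assay, at which 1 of the 4 values shown sits.

Within the data shown here, what the methoxy group itself contributes stays open, as no step from compound 1 can be read. Also open, from the compounds shown here alone, is how a hydroxyl group or a carboxylic acid in place of methoxy would read here.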